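The source may hold more compounds than are shown below. What is called first, only, known or untested is meant among the compounds shown, and "the series" means these compounds.

Measured compounds:
Compound 1, `CC(C)(O)C(CCC/C=C(\c1ccccc1)c1cccnc1)C(=O)O`: 42 nM
Compound 2, `O=C(O)C(CCC/C=C(\c1cccnc1)c1cccs1)c1ccccc1`: 50 nM

In an assay (Equus caballus) for inhibition of Thromboxane-A synthase (Homo sapiens), using microsomes (on this read-out higher numbers stand for weaker inhibition and lower numbers for stronger inhibition), compound 1 gives 42 nM and compound 2 gives 50 nM. Compound 2 stands with the higher of the two numbers, but its nearest neighbour is compound 1, and the gap between them lies within the scatter, so the two cannot be put in order.

Compound 3, `O=C(O)CCCC/C=C(\c1cccnc1)c1cccs1`, has not yet been tested in this assay. It differs from compound 2 by hydrogen in place of phenyl on a saturated chain carbon bound to a carbonyl carbon and a saturated chain carbon. Going by the values given here, no measured pair in this set isolates that change. Compound 1 and compound 2 carry different groups on the chain carbon bound to the carbonyl carbon and yet give numbers within the scatter of each other, which suggests that what sits at this place is tolerated. A step from compound 2 to compound 3 of the size a 1.8-fold higher number from compound 2 to compound 3 (0.26 log units; within the scatter) toward weaker inhibition is therefore expected, close to the edge of the scatter. For compound 3 the estimate in this assay is 90 nM, with a range from 30 nM to 270 nM.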

Compound 3, half-maximal inhibitory concentration: 20 nM
For compound 3 the middle estimate is 4.5-fold (0.65 log units) above the measured one, outside the stated range (below it).
By their numbers in this assay, from the lowest: compound 3; then compounds 1 and 2 (each within the scatter of the next).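

In this assay the change from phenyl to hydrogen gives a 2.5-fold lower number from compound 2 to compound 3 (0.40 log units; beyond the scatter) and so counts as a modest step, but a real one. Going by these compounds alone, this is the first pair in the set that differs only at the saturated chain carbon bound to a carbonyl carbon and a saturated chain carbon, and it shows that inhibition here does not depend on a group at this place: the chain with only hydrogen there does better than the one carrying phenyl. The data offer nothing that would account for this step.

What the compounds shown leave open is how the read-out responds to groups of intermediate size or of another kind at this place, such as a methyl or an amine, and whether any of them would match hydrogen or improve on it. As far as these compounds go, it also remains open whether the same step would appear with the other parts of the molecule changed, since this single pair reads the change against one background only.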